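Cyclopentyl Amide in Place of a Carbamoylphenyl Amide

The source may hold more compounds than are shown below. What is called first, only, known or untested is meant among the compounds shown, and "the series" means these compounds.

Measured in an assay on HEK293 cells for displacement of a labelled ligand from metabotropic glutamate receptor 5 (Rattus norvegicus); on this read-out lower numbers stand for stronger inhibition and higher numbers for weaker inhibition:
- compound 1 `NC(=O)c1ccc(C(=O)Nc2cc(-c3ccccc3)nn2-c2ccccc2)cc1` gives > 10000 nM, a limit of the assay
- compound 2 `O=C(Nc1cc(-c2ccccc2)nn1-c1ccccc1Cl)c1ccccc1` gives 500 nM
- compound 3 `COc1cccc(-n2nc(-c3ccccc3)cc2NC(=O)c2ccccc2)c1` gives 2100 nM

Compound 1 stands at the limit of > 10000 nM in this assay, at which 1 of the 3 values shown sits, the weak end of the numbers shown, with only a limit and no number. Among the measured compounds shown here, the single measured step, a 4.2-fold higher number from compound 2 to compound 3 (0.62 log units; beyond the scatter), alters the group on the aromatic nitrogen, not the amide side, so it does not bear on the change considered here. Compound 4 `O=C(Nc1cc(-c2ccccc2)nn1-c1ccccc1)C1CCCC1` differs from compound 1 by cyclopentyl in place of 4-carbamoylphenyl on a carbonyl carbon. For the measured compounds named here, no measured step touches the carbonyl carbon, so the size of the step of an at least 3.3-fold lower number from compound 1 to compound 4 (0.52 log units; beyond the scatter) is expected with little support; compounds 2 and 3, whose amides carry a plain phenyl, give numbers rather than limits, which points to a stronger result than the limit of compound 1. Compound 4 is therefore estimated at 3000 nM, within a range from 500 nM to 10000 nM.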

Compound 4, inhibition constant: 11600 nM
Estimate against measurement, compound 4: 3.9-fold (0.59 log units) below; the measured number lies above the stated range.
By their numbers in this assay, from the lowest: compound 2; then compound 3; then compound 4.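

The step from compound 1 to compound 4 cannot be read, since compound 1 carries only a limit: the limit of > 10000 nM in this assay, at which 1 of the 4 values shown sits.

The compounds shown leave open how cyclopentyl on the carbonyl carbon compares with a plain phenyl there on an otherwise identical core.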